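Carboxy in place of hydrogen on the outer phenyl ring

The source may hold more compounds than are shown below. What is called first, only, known or untested is meant among the compounds shown, and "the series" means these compounds.

Compound 1 `O=C(O)c1cc(-c2ccc(-c3ccc(F)cc3)cc2)n(-c2ccc(Cl)cc2Cl)n1` — 41300 nM in an assay on isolated protein for inhibition of methionine--tRNA ligase, cytoplasmic (Homo sapiens); a higher number here means a weaker inhibitor, a lower number a stronger inhibitor
Compound 2 `O=C(O)c1cc(-c2ccc(-c3ccccc3)cc2)n(-c2ccc(Cl)cc2Cl)n1` — 44300 nM in this assay

Compound 2 gives the higher of the two numbers, though its step of a 1.1-fold higher number from compound 1 to compound 2 (0.03 log units; within the scatter) is within the scatter. Compound 3 `O=C(O)c1cccc(-c2ccc(-c3cc(C(=O)O)nn3-c3ccc(Cl)cc3Cl)cc2)c1` differs from compound 2 by carboxy in place of hydrogen on an aromatic carbon, phenyl to 3-carboxyphenyl. Among the compounds with values here, no measured step touches this position, and the only step known, a 1.1-fold higher number from compound 1 to compound 2 (0.03 log units; within the scatter), shows no movement beyond the scatter. For compound 3, therefore, a step of a 1.5-fold lower number from compound 2 to compound 3 (0.17 log units; within the scatter) in this assay is expected, with little confidence in its direction. The estimate for compound 3 is 30000 nM, ranging from 8000 nM to 120000 nM.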

Compound 3, half-maximal inhibitory concentration: 40900 nM
Compound 3: the middle estimate sits 1.4-fold (0.13 log units) below what was measured; measured number inside the range.
By their numbers in this assay, from the lowest: compounds 3, 1 and 2 (each within the scatter of the next).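

Carboxy in place of hydrogen on the outer ring gives a 1.1-fold lower number from compound 2 to compound 3 (0.03 log units; within the scatter) in this assay, so adding this charged-free count of atoms at this position leaves the number within the scatter. Measured against the fluorinated ring, 3-carboxyphenyl in place of 4-fluorophenyl gives a 1.0-fold lower number from compound 1 to compound 3 (0.00 log units; within the scatter), so three different groups on this ring now give numbers within the scatter of one another. No supporting evidence bears on this result.

As far as these compounds go, whether an amine or a longer chain on this ring would move the number beyond the scatter remains open. Also open, from the compounds shown here alone, is how an amide in place of the carboxy group on the shared core would read in this assay.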